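The compounds below may be only part of what the source reports. "The series", "measured", "known", "first", "only" and "open" are said of these compounds alone.

Compound 1, with the structure `O=C(Nc1cccc(N2CCCC2=O)c1)C1CCCN(C(=O)c2cc(C(F)(F)F)cc(C(F)(F)F)c2)C1`, was tested in an ADME assay on PC-3 cells (Homo sapiens) for cytotoxicity, read by WST assay, tested at 100 uM (on this read-out lower numbers stand for less inhibition and higher numbers for more inhibition at the one concentration tested (going by the name of the read-out)), and compound 1 gives 0%. Two other compounds share the same core. Compound 2, with the structure `CS(=O)(=O)c1cccc(C(=O)N2CCCC(C(=O)Nc3ccc(Cl)cc3)C2)c1`, gives 2% in this assay, and compound 3, with the structure `C=Cc1cccc(C(=O)N2CCCC(C(=O)Nc3ccc(Cl)cc3)C2)c1`, gives 0%. These two differ in one place, vinyl in place of methylsulfonyl on an aromatic carbon, and that change gives a number 2 percentage points lower from compound 2 to compound 3 (within the scatter), so it makes no difference that can be trusted. Compound 1 stands level with compound 3 at the digits shown, and the two together form the lowest pair of the three; compound 2 lies within the scatter of both, so none of the three can be told apart.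

Compound 4, with the structure `COC(=O)c1cc(-c2cccc(NC(=O)C3CCCN(C(=O)c4cc(C(F)(F)F)cc(C(F)(F)F)c4)C3)c2)co1`, is not yet measured. It differs from compound 1 in one place: 5-(methoxycarbonyl)furan-3-yl in place of 2-oxopyrrolidin-1-yl on an aromatic carbon. For the measured compounds named here, no measured step concerns this change; the only measured step, between compound 2 and compound 3, alters a different part of the molecule and stays within the scatter. Since all three measured compounds sit at the bottom of the scale, compound 4 is expected to give 2%, with an expected range from 0% to 14%. This estimate amounts to an expected step of a number 2 percentage points higher from compound 1 to compound 4 (within the scatter), which is no change beyond the scatter.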

Compound 4, a percentage reported as inhibition, at one concentration (the size of the read-out at that concentration, not a potency): 0%
Beside the measured number, compound 4's estimate is 2 percentage points above it, and the stated range covers the measured number.
By their numbers in this assay, from the lowest: compounds 1, 3, 4 and 2 (each within the scatter of the next).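

In this assay, for the compounds shown here, putting 5-(methoxycarbonyl)furan-3-yl in place of 2-oxopyrrolidin-1-yl gives no change at the digits printed from compound 1 to compound 4 (within the scatter), the first measured change at this aromatic carbon of the core of compound 1. The swap brings in 9 heavy atoms in place of 6 and an aromatic ring in place of a non-aromatic one, yet the number stays at the bottom of the scale, so this position accepts both groups with no measurable effect on this read-out. No measurement shown explains this result.

On these data alone, whether an amine, a carboxylic acid or a longer alkyl chain on this aromatic carbon would give a different number remains open. With every compound shown sitting at the bottom of the scale, it is also unknown whether any group at this position can raise the number at all.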